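Phenyl for Isopropyl on the Amide Carbonyl

This account rests on a few compounds, and the source may have more. Where it says the series, first, only, none or still open, it means among the compounds named here.

Measured compounds in a functional assay on HUVEC cells (Homo sapiens) for inhibition, tested at 10 ug/mL; on this read-out lower numbers stand for a weaker effect and higher numbers for a stronger effect at the one concentration tested:
compound 1 `COc1cc(/C=C/C(=O)c2cccc(NC(=O)c3ccco3)c2)ccc1O`: 100%
compound 2 `COc1cc(/C=C/C(=O)c2cccc(NC(=O)C(C)C)c2)ccc1O`: 56%

Going by the values given here, compound 2 stands lowest of the two numbers, and its nearest neighbour is compound 1; the single step of a number 44 percentage points lower from compound 1 to compound 2 (beyond the scatter) is large and beyond the scatter. Compound 3 `COc1cc(/C=C/C(=O)c2cccc(NC(=O)c3ccccc3)c2)ccc1O` differs from compound 2 in one place: phenyl in place of isopropyl on a carbonyl carbon. Among the compounds with values here, only that step bears on this change, and it shows that an aromatic ring on this carbonyl carbon gave the higher number, so compound 3 is expected to gain in this assay, with an estimated step of a number 29 percentage points higher from compound 2 to compound 3 (beyond the scatter). Compound 3 is therefore estimated at 85%, within a range from 60% to 100%.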

Compound 3, a percentage reported as inhibition, at one concentration (the size of the read-out at that concentration, not a potency): 69%
Beside the measured number, compound 3's estimate is 16 percentage points above it; the measured number falls inside the stated range.
By their numbers in this assay, from the lowest: compound 2; then compound 3; then compound 1.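

In this assay phenyl on this carbonyl carbon gives a number 13 percentage points higher from compound 2 to compound 3 (beyond the scatter) and so recovers only part of what isopropyl lost. Furan-2-yl and phenyl are not interchangeable here, as a number 31 percentage points lower from compound 1 to compound 3 (beyond the scatter) is a larger step than the gain over isopropyl, so among these three compounds the identity of the ring counts and not only its presence. Nothing available explains the gap between these two rings.

Open, as far as these compounds go, is whether thiophen-2-yl or pyridin-3-yl would stand nearer furan-2-yl or phenyl. From the compounds shown here alone, how a cyclohexyl group would compare with isopropyl and phenyl also remains open.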